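Dropping a methyl from the pyridine ring of compound 1

The source may hold more compounds than are shown below. What is called first, only, known or untested is meant among the compounds shown, and "the series" means these compounds.

Measured so far:
compound 1, `Cc1ccnc(/C(N)=N/NC(=S)N2CCCCCC2)c1`, 8000 nM
compound 2, `N/C(=N\NC(=S)N1CCN(c2ccccn2)CC1)c1ccc(F)cn1`, 13400 nM
compound 3, `Cc1cccc(/C(N)=N/NC(=S)N2CCCC2)n1`, 4000 nM

Three thiosemicarbazide-type compounds have been tested in a functional assay on A-431 cells (Homo sapiens) for cytotoxicity, read by MTT assay, with a stated time of 72 h; a lower number here means a stronger inhibitor, a higher number a weaker inhibitor. Compound 1 gives 8000 nM in this assay. Compound 2 gives 13400 nM and compound 3 gives 4000 nM. Compound 1 sits in the middle of these three numbers, and both of the other two lie within the usual scatter of it, so the three cannot be told apart on these data.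

Compound 4, `N/C(=N\NC(=S)N1CCCCCC1)c1ccccn1`, is the next compound to be measured in this assay. It differs from compound 1 in a single place: hydrogen in place of methyl on an aromatic carbon. For the measured compounds named here, no pair of measured compounds shows this change by itself, so the size of its effect has no direct precedent here.

With only the methyl group removed and nothing in the measured set that tracks such a change, the expectation for compound 4 is a number close to that of compound 1, and the step of no change at the digits printed from compound 1 to compound 4 (within the scatter) is expected to stay within the scatter. Compound 4 is therefore estimated to give 8000 nM in this assay, somewhere in the range 3000 nM to 20000 nM.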

Compound 4, half-maximal inhibitory concentration: 3000 nM
For compound 4 the middle estimate is 2.7-fold (0.43 log units) above the measured one, and the stated range covers the measured number.
By their numbers in this assay, from the lowest: compounds 4, 3, 1 and 2 (each within the scatter of the next, the first and the last beyond it).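

In this assay, for the compounds shown here, putting hydrogen in place of the methyl group gives a 2.7-fold lower number from compound 1 to compound 4 (0.43 log units; beyond the scatter), the first step in this set that lies beyond the usual scatter. This shows that the position on the aromatic carbon, opposite the ring nitrogen, is not silent: even a change of a single heavy atom there moves the number by a modest amount, and the methyl group is not required for activity in this assay, since the compound without it gives the lower number. Nothing available here explains why the number falls when the methyl group leaves.

This single pair cannot show whether any group at this place raises the number or only the methyl group does, and an ethyl group, a chlorine atom or a methoxy group there would begin to separate those two readings. It also leaves open whether the same change would have a similar effect in compound 3, which carries a methyl group on its aromatic ring too but has a different group at the other end of the molecule.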